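A few compounds are considered here, and "the series" means these few. Any claim that something is new, unique, unknown or untested is made for them only; others in the source may bear on it.

Compound 1 `COc1ccc([C@H]2O[C@H](c3cc(OC)c(OC)c(OC)c3)[C@@H](C)[C@@H]2C)cc1OC` and compound 2 `C/C=C/c1cc(OC)c(O[C@H](C)[C@H](O)c2ccc(OC)c(OC)c2)c(OC)c1` have both been tested in a functional assay on BV-2 cells (Mus musculus) for inhibition, read by Griess assay, with stated times of 30 min and 24 h; a lower number here means a stronger inhibitor, a higher number a weaker inhibitor. In this assay compound 1 gives 125000 nM, and compound 2 gives 176000 nM; the gap between these two numbers lies within the scatter of repeated measurements, so neither compound can be called the stronger inhibitor on this evidence. Among the compounds with values here, no pair of measured compounds differing in a single place is available to show how any one change moves the number.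

Within the data shown here, the next compound, compound 3 `COc1ccc([C@H]2O[C@H](c3cc(OC)c(OC)c(OC)c3)[C@@H](C)[C@H]2C)cc1OC`, has not yet been measured. the two compounds have the same atoms and bonds and differ only in configuration as drawn: 1 of 4 stereo elements differ; a stereocentre at a saturated ring carbon is drawn S in compound 1 and R in compound 3 Since no measured pair shows what a change in configuration alone does here, the step of a 1.0-fold higher number from compound 1 to compound 3 (0.02 log units; within the scatter) is expected to stay within the scatter, with no clear direction. Compound 3 is therefore estimated at 130000 nM, with a likely range from 50000 nM to 350000 nM.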

Compound 3, half-maximal inhibitory concentration: 21500 nM
Beside the measured number, compound 3's estimate is 6.0-fold (0.78 log units) above it, outside the stated range (below it).
By their numbers in this assay, from the lowest: compound 3; then compounds 1 and 2 (each within the scatter of the next).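

In this assay, turning a stereocentre at a saturated ring carbon from S to R gives a 5.8-fold lower number from compound 1 to compound 3 (0.76 log units; beyond the scatter). Within the data shown here, this is the first single change here whose effect can be read, and it shows that the configuration at this one position can by itself move the number beyond the scatter, towards a stronger inhibitor. The step can be assigned to this stereocentre alone because no atom or bond changes: the fact that compounds 1 and 3 differ only in the configuration as drawn

Why the R configuration gives the lower number stays open, and so does the contribution of the other three stereo elements, none of which is changed on its own in these compounds. Also open, from the compounds shown here alone, is whether an amine or a carboxylic acid on the shared core, with the R configuration kept, would lower the number further.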